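Replacing a Benzylic Dimethylamine with an Amidine

The source may hold more compounds than are shown below. What is called first, only, known or untested is meant among the compounds shown, and "the series" means these compounds.

In an assay on isolated protein for inhibition of ubiquitin carboxyl-terminal hydrolase 7 (Homo sapiens), with stated times of 30 min and 2 h (on this read-out higher numbers stand for weaker inhibition and lower numbers for stronger inhibition), compound 3 `CN(C)Cc1ccc(-c2c3ncn(CC4(O)CCN(Cc5ccc(-c6ccco6)cc5Cl)CC4)c(=O)c3nn2C)cc1` gives 131 nM, the highest of the three numbers. Compound 1 `Cn1nc2c(=O)n(CC3(O)CCN(Cc4ccc(-c5ccco5)cc4Cl)CC3)cnc2c1-c1ccc(C2(N)CC2)cc1` gives 66.1 nM and compound 2 `Cn1nc2c(=O)n(CC3(O)CCN(Cc4ccc(-c5ccco5)cc4Cl)CC3)cnc2c1-c1ccc(CNCCO)cc1` gives 8.2 nM. Compound 4 `Cn1nc2c(=O)n(CC3(O)CCN(Cc4ccc(-c5ccco5)cc4Cl)CC3)cnc2c1-c1ccc(C(=N)N)cc1` carries a group of 3 heavy atoms (1 carbon, 2 nitrogen; no ring) in place of a group of 4 heavy atoms (3 carbon, 1 nitrogen; no ring), on an aromatic carbon, para to a large group. Among the measured compounds shown here, two measured steps bear on this change. a 16-fold higher number from compound 2 to compound 3 (1.20 log units; beyond the scatter) accompanied the exchange of a side chain holding a hydrogen-bond donor for one without, while a 2.0-fold higher number from compound 1 to compound 3 (0.30 log units; within the scatter) separated a primary amine from a dimethylamine. For the measured compounds named here, the incoming group carries two hydrogen-bond donors, so a return toward lower numbers seems plausible, though no measured pair tests an amidine directly. For compound 4 a step of a 4.4-fold lower number from compound 3 to compound 4 (0.64 log units; beyond the scatter) is expected. Compound 4 is accordingly estimated at 30 nM, within a range from 8 nM to 130 nM.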

Compound 4, half-maximal inhibitory concentration: 87.5 nM
The estimate for compound 4 lay 2.9-fold (0.46 log units) below the measured number; low and high end bracket the measured number.
By their numbers in this assay, from the lowest: compound 2; then compounds 1, 4 and 3 (each within the scatter of the next).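

Adding two hydrogen-bond donors in the amidine did not by itself restore the low number seen with compound 2: the change gave a 1.5-fold lower number from compound 3 to compound 4 (0.18 log units; within the scatter) and left compound 4 level with the aminocyclopropyl compound, with a 1.3-fold higher number from compound 1 to compound 4 (0.12 log units; within the scatter). The ((2-hydroxyethyl)amino)methyl side chain remains clearly apart, with an 11-fold higher number from compound 2 to compound 4 (1.03 log units; beyond the scatter), so a donor count alone does not order these groups. No supporting data explain that gap.

From the compounds shown here alone, it remains open whether the hydroxyl or the nitrogen-bound hydrogen of that chain matters more. A (2-methoxyethyl)aminomethyl or a methylaminomethyl group at this position would help separate the two.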